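Toxicity notes: bromo on the phenyl of compound 3

The compounds below may be only part of what the source reports. "The series", "measured", "known", "first", "only" and "open" are said of these compounds alone.

Compound 3 `COc1ccc(-c2cnc(NC(=O)c3ccccc3)n2C)cc1` carries a phenyl on the carbonyl carbon of the shared core. In a toxicity assay on THP-1 cells (Homo sapiens) for inhibition (a higher number here means that more compound is tolerated, a lower number that less compound is tolerated), compound 3 gives > 100000 nM, which is a limit of the assay and not a number. Compound 1 `COc1ccc(-c2cnc(NC(=O)C3CCCCC3)n2C)cc1` has cyclohexyl in that position, and in this assay compound 1 gives > 100000 nM, again a limit. Compound 2 `COc1ccc(-c2cnc(NC(=O)c3cccnc3)n2C)cc1` has pyridin-3-yl there, and in this assay compound 2 gives > 100000 nM, also a limit. The steps a step that the two limits leave unreadable from compound 1 to compound 3 and a step that the two limits leave unreadable from compound 2 to compound 3 cannot be read, since every value sits at the limit of > 100000 nM in this assay, at which 3 of the 3 values shown sit.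

Compound 4 `COc1ccc(-c2cnc(NC(=O)c3ccccc3Br)n2C)cc1` is not yet measured: bromo in place of hydrogen on an aromatic carbon. Among the compounds with values here, no measured step involves a bromo, so none bears on it directly; all three exchanges on the carbonyl carbon have left the compounds tolerated up to the limit. The expectation is therefore that compound 4 stays in the same region, with the step of a number no higher from compound 3 to compound 4 (the limit leaves the size open) expected to be none beyond the scatter. For compound 4 the estimate in this assay is 100000 nM, with a range from 30000 nM to 300000 nM, and most likely only a limit will be reported.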

Compound 4, half-maximal cytotoxic concentration: > 100000 nM
Compound 4: no number, only a limit (the forecaster's own chance of this, stated with the estimate: 75%); the middle value sits exactly at the limit.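

No step among compound 1, compound 2, compound 3 and compound 4 can be read in this assay, since each value is a limit and not a number: the limit of > 100000 nM in this assay, at which 4 of the 4 values shown sit.

The compounds shown leave open whether any exchange on the carbonyl carbon of the shared core changes tolerance in this assay, and by how much.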